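The source may hold more compounds than are shown below. What is called first, only, known or untested is meant among the compounds shown, and "the series" means these compounds.

Measured compounds in a functional assay on ileum for antagonist activity at muscarinic acetylcholine receptor M3 (Cavia porcellus); a higher number here means a weaker inhibitor, a lower number a stronger inhibitor:

Compound 1 `O=C(CN1CCN(c2ccc([N+](=O)[O-])cc2)CC1)C(O)(c1ccccc1)C1CCC1`: in this assay compound 1 gives > 10000 nM, which is a limit of the assay rather than a number (the limit of > 10000 nM in this assay, at which 1 of the 3 values shown sits).
Compound 2 `C=CCN1CCN(CC(=O)C(O)(c2ccccc2)C2CCCCC2)CC1`: in this assay compound 2 gives 25.6 nM.
Compound 3 `O=C(CN1CCC(N2CCCC2)CC1)C(O)(c1ccccc1)C1CCCCC1`: in this assay compound 3 gives 349 nM.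

Compound 3 stands highest of the two numbers; compound 2 sits well below it, beyond the scatter. Compound 4 `O=C(CN1CCC(N2CCCC2)CC1)C(O)(c1ccccc1)C1CCC1` differs from compound 3 in one place: cyclobutyl in place of cyclohexyl on a saturated chain carbon bound to an aromatic carbon, a carbonyl carbon and an oxygen on a saturated carbon. Among the measured compounds shown here, no measured pair covers this change. Compound 1 also carries a cyclobutyl and reached only a limit, which is suggestive but not a step. The change is expected to weaken inhibition: the step of a 5.2-fold higher number from compound 3 to compound 4 (0.71 log units; beyond the scatter) is estimated to raise the number beyond the scatter. Compound 4 is therefore expected at 1800 nM, within 500 nM to 6500 nM.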

Compound 4, antagonist equilibrium constant: > 10000 nM
Compound 4 ended at the assay's limit; the forecaster's own chance of this, stated with the estimate: 15%; middle value at least 5.5-fold (0.74 log units) away from the limit.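

In this assay, among the compounds shown here, cyclobutyl in place of cyclohexyl on this saturated chain carbon gives an at least 28-fold higher number from compound 3 to compound 4 (1.45 log units; beyond the scatter), the first step that can be read at this position. On the core of compound 3, this one change takes a measured number to a limit. Compound 4 stands at a limit and not a number, so the full size of the step stays unknown: the limit of > 10000 nM in this assay, at which 2 of the 4 values shown sit.

From the compounds shown here alone, whether cyclopentyl on this carbon keeps a measurable number remains open. Also open, going by these compounds, is whether the core of compound 2 responds to cyclobutyl in the same way.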